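Working notes: chloro for hydrogen in a cytotoxicity series

This account rests on a few compounds, and the source may have more. Where it says the series, first, only, none or still open, it means among the compounds named here.

Measured so far in a functional assay on MDA-MB-435 cells (Homo sapiens) for cytotoxicity, read by sulforhodamine B assay, with a stated time of 48 h; on this read-out higher numbers stand for lower toxicity in this test and lower numbers for higher toxicity in this test:
compound 1 `ClCc1ccccc1Cn1cnc2c(Cl)nc(Cl)nc21` gives 6450 nM
compound 2 `ClCc1ccccc1Cn1cnc2c(Cl)ncnc21` gives 36300 nM
compound 3 `ClCc1cccc(Cn2cnc3ncnc(Cl)c32)c1` gives 39800 nM

Compound 2 and compound 1 differ by one change, (chloro in place of hydrogen on an aromatic carbon), and in this assay the step is a 5.6-fold lower number from compound 2 to compound 1 (0.75 log units; beyond the scatter). Compound 3 and compound 2 have the same atoms joined differently; the difference between the two cores is not broken down here. In this assay compound 3 and compound 2 lie within the scatter of each other.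

Compound 4 `ClCc1cccc(Cn2cnc3nc(Cl)nc(Cl)c32)c1` is not yet measured. From compound 3 it differs by chloro in place of hydrogen on an aromatic carbon, the same change as from compound 2 to compound 1, with the place described in identical words. Because the earlier step was a 5.6-fold lower number from compound 2 to compound 1 (0.75 log units; beyond the scatter), the expected step in this assay is a 5.6-fold lower number from compound 3 to compound 4 (0.75 log units; beyond the scatter), resting on that single precedent only. Compound 4 is therefore estimated at 7100 nM, expected between 3000 nM and 18000 nM.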

Compound 4, concentration lethal to 50% of the cells: 5240 nM
Estimate against measurement, compound 4: 1.4-fold (0.13 log units) above; low and high end bracket the measured number.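

In this assay chloro in place of hydrogen on an aromatic carbon gives a 7.6-fold lower number from compound 3 to compound 4 (0.88 log units; beyond the scatter) and matches the earlier step on the other core: the same change on two cores in this assay, a 5.6-fold lower number (0.75 log units; beyond the scatter) from compound 2 to compound 1 and a 7.6-fold lower number (0.88 log units; beyond the scatter) from compound 3 to compound 4, 1.3-fold (0.13 log units) apart, within the scatter of two such steps

The change therefore carries across these two cores with a similar size, towards higher toxicity in this test. This rests on two matched pairs in one cell line and does not show that it would hold on any other core or at any other place. It also gives no cause for the step.

Still open, going by these compounds, is whether an amine, a methoxy group or a longer chain at that ring carbon would shift the number as chloro does. On these data alone, whether the step holds in other cell lines also remains open.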